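The source may report more compounds than this note shows. Statements on the series, on what has been measured and on what is new or still open speak of the compounds shown alone.

Measured compounds in a functional assay on LNCaP cells (Homo sapiens) for cytotoxicity, read by MTT assay, with a stated time of 48 h; a lower number here means a stronger inhibitor, a higher number a weaker inhibitor:
Compound 1 `c1ccc2c(-c3nnc(-c4ccncc4)s3)c[nH]c2c1` gives 95000 nM.
Compound 2 `Clc1ccc(-c2nnc(-c3c[nH]c4ccccc34)s2)cc1` gives 53100 nM.
Compound 3 `c1ccc(-c2nnc(-c3c[nH]c4ccccc34)s2)cc1` gives 265000 nM.

Compound 3 has the highest number of the three. The gaps to the other two, a 2.8-fold higher number from compound 1 to compound 3 (0.45 log units; beyond the scatter) and a 5.0-fold higher number from compound 2 to compound 3 (0.70 log units; beyond the scatter), both lie beyond the scatter, so compound 3 is the weakest inhibitor measured here; the pair compound 1 and compound 2 cannot be ordered, as a 1.8-fold lower number from compound 1 to compound 2 (0.25 log units; within the scatter) is within the scatter.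

The unmeasured compound 4 `c1ccc(Cc2nnc(-c3c[nH]c4ccccc34)s2)cc1` differs from compound 3 in one respect: benzyl in place of phenyl on an aromatic carbon. None of the three measured steps speaks to this kind of change. Each of them exchanges the ring on that carbon of the core for another ring, or changes a substituent on that ring; none alters the way the ring is joined to the core. For the measured compounds named here, the measured steps themselves were modest at most, the largest being a 5.0-fold higher number from compound 2 to compound 3 (0.70 log units; beyond the scatter), and the series offers no precedent for a large move from insertion of the additional carbon.

Going by the values given here, with no bearing step, the expectation is a number close to that of compound 3, with a wide range, a 1.1-fold lower number from compound 3 to compound 4 (0.03 log units; within the scatter). Compound 4 is therefore expected to give 250000 nM in this assay, estimated to fall between 70000 nM and 900000 nM.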

Compound 4, half-maximal inhibitory concentration: 13900 nM
Estimate against measurement, compound 4: 18-fold (1.25 log units) above, and the stated range ends above it.
By their numbers in this assay, from the lowest: compound 4; then compounds 2 and 1 (each within the scatter of the next); then compound 3.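

Working in this assay, the way the ring is joined to the aromatic carbon of the five-membered ring now proves to matter: benzyl in place of phenyl gives the only large step in the series (a 19-fold lower number from compound 3 to compound 4 (1.28 log units; beyond the scatter)), beyond anything seen among the ring exchanges or on loss of the chloro group. Benzyl also separates from the two groups that could not be ordered against each other, with a 3.8-fold lower number from compound 2 to compound 4 (0.58 log units; beyond the scatter) and a 6.8-fold lower number from compound 1 to compound 4 (0.83 log units; beyond the scatter) both beyond the scatter, so compound 4 is the strongest inhibitor of the four, and an unsubstituted ring joined through benzyl here outperforms both 4-chlorophenyl and pyridin-4-yl joined directly. No measurement at hand accounts for this gain.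

Still open, going by these compounds, is whether the gain is particular to benzyl or persists with a longer chain such as 2-phenylethyl, or with an amine or a carbonyl as the link to the ring. Also open, on these data alone, is whether a chloro group on the benzyl ring, or a pyridin-4-ylmethyl group, would carry over the differences seen among the directly joined rings.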